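A few compounds are considered here, and "the series" means these few. Any claim that something is new, unique, unknown or untested is made for them only; others in the source may bear on it.

Of the compounds shown here, three of one shared core have been measured in an ADME assay on the whole organism for inhibition, with Echinochloa crus-galli var. formosensis as the target, with a stated time of 4 days; on this read-out lower numbers stand for stronger inhibition and higher numbers for weaker inhibition. Compound 1 `CC[C@@H](C)Nc1nc(Cl)nc(N[C@@H](C)c2ccccc2)n1` gives 7410 nM in this assay. Its mirror-drawn partner compound 2 `CC[C@H](C)Nc1nc(Cl)nc(N[C@@H](C)c2ccccc2)n1` gives 14100 nM. The step of a 1.9-fold higher number from compound 1 to compound 2 (0.28 log units; within the scatter) rests on the fact that compounds 1 and 2 differ only in the configuration as drawn and tells nothing of use here. Compound 3 `CC(C)N(c1nc(Cl)nc(N[C@@H](C)c2ccccc2)n1)C(C)C` gives 110 nM and holds the lowest number of the three, standing beyond the scatter from both others, so it is the strongest inhibitor shown: the steps of a 67-fold lower number from compound 1 to compound 3 (1.83 log units; beyond the scatter) and a 130-fold lower number from compound 2 to compound 3 (2.11 log units; beyond the scatter) are both large.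

Compound 4 `CCCN(CCC)c1nc(Cl)nc(N[C@@H](C)c2ccccc2)n1` is not yet measured. It differs from compound 3 by dipropylamino in place of diisopropylamino on an aromatic carbon. Within the data shown here, no measured step compares two dialkylamino groups, so the change from branched to straight chains has no direct precedent; the only large steps concern the move from a single (sec-butyl) to the diisopropyl group. A modest step toward weaker inhibition is therefore expected, a 2.3-fold higher number from compound 3 to compound 4 (0.36 log units; beyond the scatter). For compound 4 the estimated value in this assay is 250 nM, with a likely range from 70 nM to 1200 nM.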

Compound 4, half-maximal inhibitory concentration: 100 nM
Beside the measured number, compound 4's estimate is 2.5-fold (0.40 log units) above it, and the stated range covers the measured number.
By their numbers in this assay, from the lowest: compounds 4 and 3 (each within the scatter of the next); then compounds 1 and 2 (each within the scatter of the next).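

In this assay, putting the straight-chain dipropylamino in place of the branched diisopropylamino, with the same atoms joined differently, changes nothing that can be told apart: a 1.1-fold lower number from compound 3 to compound 4 (0.04 log units; within the scatter). At this position, the large distance from the (sec-butyl)amino compounds therefore holds for the straight chains as well as the branched ones, as shown by a 74-fold lower number from compound 1 to compound 4 (1.87 log units; beyond the scatter) and by a 140-fold lower number from compound 2 to compound 4 (2.15 log units; beyond the scatter). Nothing at hand bears on why the two dialkylamino groups read alike.

Still open, as far as these compounds go, is whether shorter or longer chains on this nitrogen, such as dimethylamino or dibutylamino, would stay at this level. A single straight chain, as in propylamino, would also show how the straight dialkylamino group compares with an amino group carrying only one chain.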